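The source may hold more compounds than are shown below. What is called first, only, known or untested is meant among the compounds shown, and "the series" means these compounds.

Three compounds have been measured in an ADME assay on HPC cells (Homo sapiens) for cytotoxicity, with a stated time of 48 h; on this read-out higher numbers stand for lower toxicity in this test and lower numbers for higher toxicity in this test:

Compound 1, `Cc1c(C(=O)/C=C/c2cccc([N+](=O)[O-])c2)[n+]([O-])c2ccccc2[n+]1[O-]`: 46000 nM
Compound 2, `Cc1c(C(=O)/C=C/c2ccc(Cl)c(Cl)c2)[n+]([O-])c2ccccc2[n+]1[O-]`: 13000 nM
Compound 3, `COc1cc(/C=C/C(=O)c2c(C)[n+]([O-])c3ccccc3[n+]2[O-])cc(OC)c1OC`: 31000 nM

All three share the same core, an N-oxide bearing ring system joined through an unsaturated ketone linker to an aromatic ring; they differ only in that ring. In this assay compound 2 gives the lowest number of the three, which on this read-out means the strongest cytotoxicity seen so far. Its nearest neighbour is compound 3, whose number is higher by more than the usual scatter, and the furthest is compound 1, whose number is higher still, also beyond the scatter. So compound 2 stands apart at the toxic end of this small set.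

The next compound, compound 4, `Cc1c(C(=O)/C=C/c2ccc(Br)cc2)[n+]([O-])c2ccccc2[n+]1[O-]`, is compound 2 with 4-bromophenyl in place of 3,4-dichlorophenyl on a double-bonded chain carbon bound to a double-bonded chain carbon. Going by the values given here, no measured pair in this set isolates such a swap, so the direction of the step rests on the spread of the three numbers alone. The expectation is a step in this assay that stays within the usual scatter, perhaps leaning toward a somewhat higher number, which is a 1.5-fold higher number from compound 2 to compound 4 (0.19 log units; within the scatter). Compound 4 is therefore estimated at 20000 nM, with a likely range from 8000 nM to 50000 nM.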

Compound 4, half-maximal cytotoxic concentration: 43000 nM
Beside the measured number, compound 4's estimate is 2.2-fold (0.33 log units) below it; the range from low to high includes it.
By their numbers in this assay, from the lowest: compound 2; then compounds 3, 4 and 1 (each within the scatter of the next).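

In this assay, going by these compounds alone, putting 4-bromophenyl in place of 3,4-dichlorophenyl on a double-bonded chain carbon bound to a double-bonded chain carbon gives a 3.3-fold higher number from compound 2 to compound 4 (0.52 log units; beyond the scatter), the first step in this set in which only one group changes. It shows that this place on the molecule is sensitive to the halogens carried by the aromatic ring: the ring itself stays, two chlorine atoms leave, one bromine atom enters, and the number moves towards lower toxicity in this test by more than the usual scatter. Nothing measured here accounts for the size or direction of this step, so it stands as an observation without an explanation.

The kind of halogen and the number of halogen atoms change together in this single swap, so the step cannot show which of the two matters, and a phenyl ring carrying a single chlorine atom would be needed to separate them. From the compounds shown here alone, how this place would respond to a group of a different type, such as an amine or a carboxylic acid on the aromatic ring, also remains open.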